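The source may hold more compounds than are shown below. What is called first, only, known or untested is meant among the compounds shown, and "the series" means these compounds.

Measured compounds and their values:

Compound 1, `COc1cc(-c2nn(-c3cccc(NC(=O)Nc4cc(C(F)(F)F)cc(C(F)(F)F)c4)c3)cc2-c2ccncc2)ccc1Cl`: 1540 nM
Compound 2, `O=C(Nc1cccc(-n2cc(-c3ccncc3)c(-c3ccc(Cl)c(O)c3)n2)c1)Nc1cc(C(F)(F)F)cc(C(F)(F)F)c1`: 2660 nM
Compound 3, `COc1cc(-c2nn(-c3cccc(NC(=O)Nc4ccc(Cl)c(C(F)(F)F)c4)c3)cc2-c2ccncc2)ccc1Cl`: 4420 nM

These three compounds were tested in a functional assay on MDA-MB-468 cells (Homo sapiens) for inhibition, read by sulforhodamine B assay, with a stated time of 48 h; on this read-out higher numbers stand for weaker inhibition of growth and lower numbers for stronger inhibition of growth. Compound 1 and compound 2 differ only by hydrogen in place of methyl on an oxygen on an aromatic ring, and that change gave a 1.7-fold higher number from compound 1 to compound 2 (0.24 log units; within the scatter). Compound 3 carries a different urea-side aryl group from compound 1; the difference between the two cores is not broken down here. In this assay compound 3 gives 4420 nM, which is a higher number than compound 1 shows by a margin beyond the usual scatter, while against compound 2 the two values lie within the scatter of each other.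

Compound 4, `O=C(Nc1cccc(-n2cc(-c3ccncc3)c(-c3ccc(Cl)c(O)c3)n2)c1)Nc1ccc(Cl)c(C(F)(F)F)c1`, has not yet been measured. It stands to compound 3 as compound 2 stands to compound 1: the difference is hydrogen in place of methyl on an oxygen on an aromatic ring, the same change at the same kind of place, with the same neighbouring aromatic carbon. Among the compounds with values here, only one earlier instance of this change is available, so the expectation rests on a single step. Compound 4 is expected to give a step of about a 1.6-fold higher number from compound 3 to compound 4 (0.21 log units; within the scatter) in this assay because the same change gave a 1.7-fold higher number from compound 1 to compound 2 (0.24 log units; within the scatter). Compound 4 is therefore estimated at 7200 nM, with a likely range from 3200 nM to 16000 nM.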

Compound 4, concentration for total growth inhibition: 1750 nM
Compound 4: the middle estimate sits 4.1-fold (0.61 log units) above what was measured; the whole stated range lies above it.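

In this assay, the change from methoxy to hydroxy on the core of compound 3 gave a 2.5-fold lower number from compound 3 to compound 4 (0.40 log units; beyond the scatter), whereas on the core of compound 1 it gave a 1.7-fold higher number from compound 1 to compound 2 (0.24 log units; within the scatter). Within the data shown here, the outcome of this change therefore did not carry from one core to the other, and the two steps differ by more than their scatter allows: the same change on two cores in this assay, a 1.7-fold higher number (0.24 log units; within the scatter) from compound 1 to compound 2 and a 2.5-fold lower number (0.40 log units; beyond the scatter) from compound 3 to compound 4, 4.4-fold (0.64 log units) apart, beyond the scatter of two such steps This comparison rests on only two pairs, which differ in the urea-side aryl group, so it shows that the step cannot be assumed to transfer between these cores, but it does not show which feature of that aryl group is responsible, nor how the change would behave on any further core.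

The compounds shown leave open whether an amine, a fluorine or an ethoxy group in place of the hydroxy would follow either step, and whether a carboxylic acid on the urea-side aryl group would alter the outcome of the methoxy to hydroxy change. They also leave open whether the lower number from compound 3 to compound 4 would recur with other urea-side aryl groups, or whether it is confined to this one pair.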